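From a Limit to a Longer Chain

This account rests on a few compounds, and the source may have more. Where it says the series, first, only, none or still open, it means among the compounds named here.

In a functional assay on A549 cells (Homo sapiens) for antiproliferative activity, read by MTT assay, with a stated time of 72 h (a higher number here means a weaker inhibitor, a lower number a stronger inhibitor), the measured compounds are:
- compound 1 `CCCCCCCCCCCCNC[C@@H]1OC[C@H](N)[C@H]1O` with 41100 nM as its value
- compound 2 `CCCCCCCCCNC[C@@H]1OC[C@H](N)[C@H]1O` with > 128000 nM as its value

For compound 2, > 128000 nM is a limit of the assay and not a number. Compound 3 `CCCCCCCCCCCCCCNC[C@@H]1OC[C@H](N)[C@H]1O` differs from compound 2 by pentyl in place of hydrogen on a saturated chain carbon, nine bonds along the chain from an amine nitrogen in the chain. Going by the values given here, one measured step bears on this, at the same place but with hydrogen in place of propyl: an at least 3.1-fold higher number from compound 1 to compound 2 (0.49 log units; beyond the scatter) lies beyond the scatter. Read in reverse, that step from compound 1 points to a lower number in this assay when the chain grows, and a decrease of at least modest size is therefore expected, though it rests on this single step. The estimated change is an at least 6.4-fold lower number from compound 2 to compound 3 (0.80 log units; beyond the scatter) in this direction. Compound 3 is expected at about 20000 nM on this reasoning, within an estimated range of 6000 nM to 70000 nM for now.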

Compound 3, half-maximal inhibitory concentration: 20000 nM
Beside the measured number, compound 3's estimate shows no gap at the digits printed; measured number inside the range.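

In this assay, compound 3 shows that the number keeps falling past the chain of compound 1, with a 2.1-fold lower number from compound 1 to compound 3 (0.31 log units; beyond the scatter), so ethyl in place of hydrogen still gives a modest change that lies beyond the scatter. The full pentyl change gives an at least 6.4-fold lower number from compound 2 to compound 3 (0.80 log units; beyond the scatter), and among these three compounds the number falls as the chain grows, with none going against that order. The size of that larger step is only a bound, because compound 2 carries a limit of the assay and not a number: the limit of > 128000 nM in this assay, at which 1 of the 3 values shown sits.

The compounds shown leave open whether a longer chain would lower the number further or whether the fall stops at compound 3. They also leave open what an amide in place of the amine in the chain would do.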